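Benzyl to 4-chlorophenyl on a triazole: two pairs compared

This account rests on a few compounds, and the source may have more. Where it says the series, first, only, none or still open, it means among the compounds named here.

Measured compounds:
compound 1 `CCCCCc1ccc(C#Cc2c(-c3ccc(CCCCC)cc3)oc3nc(=O)n(Cc4cn(-c5ccc(Cl)cc5)nn4)cc23)cc1`, > 100000 nM
compound 2 `O=c1nc2oc(C3CC3)c(C#CC3CC3)c2cn1Cc1cn(Cc2ccccc2)nn1`, 4810 nM
compound 3 `CCCCCc1ccc(C#Cc2c(-c3ccc(CCCCC)cc3)oc3nc(=O)n(Cc4cn(Cc5ccccc5)nn4)cc23)cc1`, > 100000 nM

The study measures growth inhibition in a functional assay on A549 cells (Homo sapiens) for antiproliferative activity, read by MTT assay, with a stated time of 72 h; a lower number here means a stronger inhibitor, a higher number a weaker inhibitor. Compound 2 is the only one of the three that gives a number: in this assay compound 2 reaches 4810 nM. For compound 3 the read-out stops at the limit of the assay, > 100000 nM. For compound 1, too, only the limit is reported, > 100000 nM.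

Compound 3 and compound 1 differ by one change, (4-chlorophenyl in place of benzyl on an aromatic nitrogen). The step that the two limits leave unreadable from compound 3 to compound 1 cannot be read, because both ends sit at the limit of > 100000 nM in this assay, at which 2 of the 3 values shown sit. How the core of compound 2 differs from the core of compound 3 is not broken down here.

Compound 4 `O=c1nc2oc(C3CC3)c(C#CC3CC3)c2cn1Cc1cn(-c2ccc(Cl)cc2)nn1`, not yet measured, carries the same change on the core of compound 2: 4-chlorophenyl in place of benzyl on an aromatic nitrogen. The place lines of the two changes agree word for word, so it is the same change made a second time. Going by the values given here, the only earlier instance gives no readable size, so the expectation for compound 4 rests on the value of compound 2 alone, and the step of a 1.0-fold higher number from compound 2 to compound 4 (0.02 log units; within the scatter) is estimated to be small, within the usual scatter. In this assay compound 4 is therefore expected near 5000 nM, with a range estimated from 1200 nM to 25000 nM.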

Compound 4, half-maximal inhibitory concentration: 39000 nM
Compound 4: the middle estimate sits 7.8-fold (0.89 log units) below what was measured; the whole stated range lies below it.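

In this assay, replacing benzyl with 4-chlorophenyl on an aromatic nitrogen gives an 8.1-fold higher number from compound 2 to compound 4 (0.91 log units; beyond the scatter), so on this core the change makes the compound a weaker inhibitor by a readable margin. The same change on the core of compound 3 cannot be read, and its size there cannot be set against the size on the core of compound 2, because both ends of that earlier pair are limits rather than numbers: the limit of > 100000 nM in this assay, at which 2 of the 4 values shown sit. The series therefore offers a single readable instance of this change, which shows its effect on one core but does not show whether that effect carries from one core to another, and the data give no reason for its size.

The change removes the carbon link to the ring and adds chlorine in one step, so a plain phenyl or a 4-fluorophenyl group on the same nitrogen of the core of compound 2 would be needed to tell these two parts apart. From the compounds shown here alone, it also remains open whether a shorter chain, such as propyl in place of each pentyl on the core of compound 3, would bring that pair into a readable range and allow the change to be compared across cores.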